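The compounds below may be only part of what the source reports. "The series", "measured", "known", "first", "only" and "open" are said of these compounds alone.

Measured so far in an assay on isolated protein for inhibition of serine/threonine-protein kinase Nek1 (Homo sapiens), read by TR-FRET, with a stated time of 30 min; a higher number here means a weaker inhibitor, a lower number a stronger inhibitor:
- compound 1 `CCN(CC)CCNS(=O)(=O)c1ccc(-c2ccnc3[nH]ccc23)cc1`: 10000 nM
- compound 3 `CN(CCO)S(=O)(=O)c1ccc(-c2ccnc3[nH]ccc23)cc1`: 2700 nM
- compound 2 `COCCNS(=O)(=O)c1ccc(-c2ccnc3[nH]ccc23)cc1`: a limit only, > 30000 nM

Compound 2 stands apart from the other two: in this assay compound 2 returns no number, only the limit > 30000 nM. It is the single case at the limit of > 30000 nM in this assay, at which 1 of the 3 values shown sits, so any comparison that starts from compound 2 is open-ended on that side.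

Among the measured compounds shown here, two measured steps touch compound 2. Going from compound 1 to compound 2, where methoxy replaces diethylamino on the chain, gives an at least 3.0-fold higher number from compound 1 to compound 2 (0.47 log units; beyond the scatter). Going from compound 2 to compound 3 gives an at least 11-fold lower number from compound 2 to compound 3 (1.04 log units; beyond the scatter). Both point the same way: the (2-methoxyethyl)amino group sits at the weak end of what has been measured, and either of the two other sulfonamide substituents reads as a lower number.

Compound 4 `CN1CCN(S(=O)(=O)c2ccc(-c3ccnc4[nH]ccc34)cc2)CC1` is not yet measured. It differs from compound 2 as 4-methylpiperazin-1-yl in place of (2-methoxyethyl)amino on a sulfonyl sulfur. The methoxy chain leaves; what enters is a ring bearing two nitrogens and no hydrogen-bond donor, closer in kind to the diethylamino-bearing compound 1 than to compound 2. The expected direction in this assay is therefore downward from the limit, with a size at least that of the step from compound 1 to compound 2, and plausibly nearer that seen for compound 3. The estimate implies a step of an at least 6.0-fold lower number from compound 2 to compound 4 (0.77 log units; beyond the scatter). Compound 4 is expected at 5000 nM, with a range from 1500 nM to 20000 nM.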

Compound 4, half-maximal inhibitory concentration: > 10000 nM
Compound 4: no number, only a limit; the forecaster's own chance of this, stated with the estimate: 20%; middle value at least 2.0-fold (0.30 log units) away from the limit.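

In this assay compound 4 returns only a limit, > 10000 nM, and no number. Set against the (2-hydroxyethyl)(methyl)amino group on the sulfonyl sulfur, 4-methylpiperazin-1-yl gives an at least 3.7-fold higher number from compound 3 to compound 4 (0.56 log units; beyond the scatter), so a sulfonamide nitrogen without a hydrogen, which compound 3 and compound 4 share, does not on its own bring the lower number of compound 3; among the four compounds, only compound 3 now has a measured value below that of compound 1. Set against the (2-(diethylamino)ethyl)amino group on the sulfonyl sulfur, 4-methylpiperazin-1-yl gives a number no lower from compound 1 to compound 4 (the limit leaves the size open). The step to compound 4 from compound 2 cannot be read, since compound 4 holds only a limit: the limit of > 10000 nM in this assay, at which 1 of the 4 values shown sits.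

Going by these compounds, whether the hydroxyl of compound 3 or its methyl on the sulfonamide nitrogen goes with the lower number stays open, and the plain (2-hydroxyethyl)amino group would separate the two. A 4-hydroxypiperidin-1-yl group on the sulfonyl sulfur would show whether a hydroxyl keeps that lower number when the nitrogen sits in a six-membered ring, which compound 4 alone cannot answer.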